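A few compounds are considered here, and "the series" means these few. Any claim that something is new, unique, unknown or untested is made for them only; others in the source may bear on it.

In a functional assay on NB1 cells (Homo sapiens) for cytotoxicity, read by MTT assay, with a stated time of 3 days (on this read-out lower numbers stand for stronger inhibition and higher numbers for weaker inhibition), three compounds have been measured: compound 1 (`N#Cc1c(O)nc(SCc2nc3ccccc3[nH]2)nc1-c1ccccc1`) gives 6.57 nM, compound 2 (`N#Cc1c(Cl)nc(SCc2nc3ccccc3[nH]2)nc1-c1ccccc1`) gives 2.87 nM, and compound 3 (`N#Cc1c(Nc2ccccn2)nc(SCc2nc3ccccc3[nH]2)nc1-c1ccccc1`) gives 3.9 nM. The value for compound 3 lies within the scatter of both others. Compound 4 (`N#Cc1c(Nc2nccs2)nc(SCc2nc3ccccc3[nH]2)nc1-c1ccccc1`) has 1,3-thiazol-2-yl in place of pyridin-2-yl on a nitrogen on an aromatic ring. For the measured compounds named here, no measured step makes this exchange. The nearest evidence comes from changes on an aromatic carbon, all small: a 2.3-fold lower number from compound 1 to compound 2 (0.36 log units; beyond the scatter), a modest step, then a 1.7-fold lower number from compound 1 to compound 3 (0.23 log units; within the scatter) and a 1.4-fold higher number from compound 2 to compound 3 (0.13 log units; within the scatter), both within the scatter. No step beyond the scatter is therefore expected in this assay. The estimated step is a 1.0-fold lower number from compound 3 to compound 4 (0.01 log units; within the scatter). Compound 4 is expected at 3.8 nM, with an estimated range of 1.8 nM to 8 nM.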

Compound 4, half-maximal inhibitory concentration: 3.2 nM
For compound 4 the middle estimate is 1.2-fold (0.07 log units) above the measured one; low and high end bracket the measured number.
By their numbers in this assay, from the lowest: compounds 2, 4, 3 and 1 (each within the scatter of the next, the first and the last beyond it).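

The exchange on the nitrogen itself gives a 1.2-fold lower number from compound 3 to compound 4 (0.09 log units; within the scatter) in this assay, so here a five-membered aromatic ring with two hetero atoms reads the same as a six-membered one with one. Replacing chloro on the aromatic carbon with (1,3-thiazol-2-yl)amino gives a 1.1-fold higher number from compound 2 to compound 4 (0.05 log units; within the scatter), whereas replacing hydroxy gives a 2.1-fold lower number from compound 1 to compound 4 (0.31 log units; beyond the scatter), a modest step beyond the scatter that (pyridin-2-yl)amino did not reach. Nothing given accounts for these values. Going by these compounds, it remains open how a plain phenyl on that nitrogen, or a morpholine on the aromatic carbon, would read.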